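Compound 1 to compound 4: carbamoyl to methoxycarbonyl

The source may hold more compounds than are shown below. What is called first, only, known or untested is meant among the compounds shown, and "the series" means these compounds.

Measured so far in an ADME assay on HEK293 cells (Homo sapiens) for cytotoxicity, with a stated time of 72 h (on this read-out higher numbers stand for an effect only at larger amounts of compound and lower numbers for an effect already at smaller amounts), for three compounds:
- compound 1 `Cc1cc(NC(=O)Nc2cccc(C(N)=O)c2)c2ccccc2n1` gives > 25000 nM as a limit, not a number
- compound 2 `COC(=O)c1ccc(NC(=O)Nc2cc(C)nc3ccccc23)cc1` gives 15000 nM as a number
- compound 3 `COc1ccc(NC(=O)Nc2cc(C)nc3ccccc23)cc1F` gives > 25000 nM as a limit, not a number

Compound 1 sits on the limit of > 25000 nM in this assay, at which 2 of the 3 values shown sit, and has no number of its own. Compound 4 `COC(=O)c1cccc(NC(=O)Nc2cc(C)nc3ccccc23)c1` is still to be measured. It differs from compound 1 as follows: methoxy in place of amino on a carbonyl carbon with methoxy in place of amino on a carbonyl carbon. Among the compounds with values here, no measured step covers this change. Within the data shown here, compound 2, which also carries methoxycarbonyl, gives 15000 nM as the only number in the set. A modest move to lower numbers is therefore expected in this assay as the likely direction, although a limit remains possible. The expected change is an at least 1.5-fold lower number from compound 1 to compound 4 (0.19 log units; that floor lies within the scatter) as a rough estimate. For compound 4 the estimated value is 16000 nM within an expected range of 8000 nM to 25000 nM in this series.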

Compound 4, half-maximal effective concentration: 26000 nM
Beside the measured number, compound 4's estimate is 1.6-fold (0.21 log units) below it, outside the stated range (above it).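

No step from compound 1 to compound 4 can be read in this assay, because compound 1 has only a limit, not a number: the limit of > 25000 nM in this assay, at which 2 of the 4 values shown sit.

The compounds shown leave open how far methoxycarbonyl and carbamoyl differ on this read-out.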